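The source may report more compounds than this note shows. Statements on the series, on what has been measured and on what is new or still open speak of the compounds shown alone.

Compound 1 `CCCCc1cn(C[C@H](O)[C@H]2OC(=O)C(OCc3ccccc3)=C2OCc2ccccc2)nn1` is the anchor of this set. For the measured compounds named here, in a functional assay on SW-620 cells (Homo sapiens) for antiproliferative activity, read by MTT assay, with a stated time of 72 h (a higher number here means a weaker inhibitor, a lower number a stronger inhibitor), compound 1 gives 47500 nM, and among the three values shown it is the only one that is a number rather than a limit. Compound 2 `COc1ccccc1-c1cn(C[C@H](O)[C@H]2OC(=O)C(OCc3ccccc3)=C2OCc2ccccc2)nn1` is one of the two neighbours; in this assay compound 2 reaches only a limit, > 100000 nM. Compound 3 `O=C1O[C@H]([C@@H](O)Cn2ccnn2)C(OCc2ccccc2)=C1OCc1ccccc1` is the other; in this assay compound 3 likewise reaches only a limit, > 100000 nM. The two steps away from compound 1 are therefore both readable only as bounds: an at least 2.1-fold higher number from compound 1 to compound 2 (0.32 log units; beyond the scatter), and an at least 2.1-fold higher number from compound 1 to compound 3 (0.32 log units; beyond the scatter). The step between the two neighbours is a step that the two limits leave unreadable from compound 2 to compound 3, because of the limit of > 100000 nM in this assay, at which 2 of the 3 values shown sit.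

Compound 4 `O=C1O[C@H]([C@@H](O)Cn2cc(CNS(=O)(=O)c3ccc(Cl)cc3F)nn2)C(OCc2ccccc2)=C1OCc1ccccc1` has not yet been measured in this assay. Compared with compound 1 it carries a change at the same arm of the shared core: ((4-chloro-2-fluorophenyl)sulfonyl)amino in place of propyl on a saturated chain carbon bound to an aromatic carbon. Both measured changes at this arm, one enlarging the butyl and one removing it, moved the number at least to the limit. Neither tells how this particular group will behave, so the expectation rests on the weak starting point alone. Compound 4 is expected to give 65000 nM, within 15000 nM to 250000 nM. The step expected from compound 1 to compound 4 is a 1.4-fold higher number from compound 1 to compound 4 (0.14 log units; within the scatter).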

Compound 4, half-maximal inhibitory concentration: 42400 nM
Estimate against measurement, compound 4: 1.5-fold (0.19 log units) above; measured number inside the range.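

For the compounds shown here, the step at this arm (a 1.1-fold lower number from compound 1 to compound 4 (0.05 log units; within the scatter)) is the first among the changes to the butyl group that can be read as a number, and it lies within the scatter. It shows that in this assay this arm can take ((4-chloro-2-fluorophenyl)sulfonyl)amino in place of propyl, with its aromatic ring, hydrogen-bond donor and 12 heavy atoms against 3, and the reading stays level with that of compound 1. The earlier compounds shown here gave no such reading, since compound 2 and compound 3 each stop at a limit of the assay, and the steps to them give only bounds: the limit of > 100000 nM in this assay, at which 2 of the 4 values shown sit.

The compounds shown leave open which part of the new group allows this result, the sulfonyl amino link or the chlorofluorophenyl ring, and a plain phenyl ring or an amide link in the same place would begin to separate the two. They also leave open whether any group at this arm, such as an amine or a carboxylic acid, would bring the number clearly below that of compound 1.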